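The compounds below may be only part of what the source reports. "The series", "measured", "known", "first", "only" and "open" are said of these compounds alone.

Measured so far:
compound 1 `CC(C)COc1cc(-c2ccccc2)nc2ccccc12` — a functional assay on P388 cells (Mus musculus) for cytotoxicity; a higher number here means that more compound is needed for the effect, a lower number that less compound is needed: > 10 ug/mL, a limit of the assay
compound 2 `CS(=O)(=O)Oc1cc(-c2ccccc2)nc2ccccc12` — this assay: > 10 ug/mL, a limit of the assay

Compound 2 stands only at a limit in this assay, with no number behind it. Within the data shown here, the single measured step, a step that the two limits leave unreadable from compound 1 to compound 2, cannot be read because of the limit of > 10 ug/mL in this assay, at which 2 of the 2 values shown sit; it neither shows a gain nor a loss for exchanging the isobutyl for the methylsulfonyl.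

Compound 3 `CC(C)Oc1cc(-c2ccccc2)nc2ccccc12` differs from compound 2 as follows: isopropyl in place of methylsulfonyl on an oxygen on an aromatic ring. The step from compound 1 to compound 2 is the only one that bears on this change, as it also exchanges an alkyl for methylsulfonyl on the same oxygen, and its size is not readable. No step beyond the scatter is therefore expected here. For compound 3 the expected step is a step that the limit leaves unreadable from compound 2 to compound 3, and the expected result is 20 ug/mL, between 8 ug/mL and 50 ug/mL, most likely again reported only as a limit.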

Compound 3, half-maximal effective concentration: > 10 ug/mL
Compound 3 was reported as a limit; the forecaster's own chance of this, stated with the estimate: 80%; the middle value lies beyond the limit too.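

In this assay, compound 3 gives > 10 ug/mL, a limit of the assay. The steps among compound 1, compound 2 and compound 3 cannot be read: the limit of > 10 ug/mL in this assay, at which 3 of the 3 values shown sit.

The compounds shown leave open how isobutyl, methylsulfonyl and isopropyl on this oxygen rank, and whether any of them gives a measurable value.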